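A few compounds are considered here, and "the series" means these few. Any claim that something is new, unique, unknown or untested is made for them only; others in the source may bear on it.

Measured so far:
Compound 1, `Cc1ccc(-n2nc(-c3ccccc3)nc2CNc2ccc(C(=O)NO)cc2)cc1`: 310 nM
Compound 2, `COc1ccc(-n2nc(-c3ccc(O)cc3)nc2CNc2ccc(C(=O)NO)cc2)cc1`: 102 nM

In an assay on Sf9 cells for inhibition of protein deacetylase HDAC6 (Homo sapiens), read by fluorescence, with a stated time of 40 min (on this read-out higher numbers stand for weaker inhibition and lower numbers for stronger inhibition), compound 1 gives 310 nM, the higher of the two numbers recorded. Compound 2 gives 102 nM in this assay, a lower number, and the gap between the two lies beyond the usual scatter. The two compounds differ from each other at more than one place, however, so their gap cannot be tied to any single change and only shows that the shared core allows numbers across this span.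

Compound 3, `Cc1cccc(-n2nc(-c3ccccc3)nc2CNc2ccc(C(=O)NO)cc2)c1`, differs from compound 1 in one place only: 3-methylphenyl in place of 4-methylphenyl on an aromatic nitrogen. Among the compounds with values here, no measured pair shows the effect of this change on its own, so the step has to be judged from the nature of the change alone. The same atoms are joined differently and nothing else moves. The step from compound 1 to compound 3 is expected to be small, in either direction, and most likely not beyond the scatter, at a 1.0-fold lower number from compound 1 to compound 3 (0.01 log units; within the scatter). For compound 3 in this assay the estimate is 300 nM, with a range from 120 nM to 750 nM.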

Compound 3, half-maximal inhibitory concentration: 388 nM
Beside the measured number, compound 3's estimate is 1.3-fold (0.11 log units) below it, and the stated range covers the measured number.
By their numbers in this assay, from the lowest: compound 2; then compounds 1 and 3 (each within the scatter of the next).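

In this assay, within the data shown here, 3-methylphenyl in place of 4-methylphenyl on the aromatic nitrogen gives a 1.3-fold higher number from compound 1 to compound 3 (0.10 log units; within the scatter), and this is the first comparison in the set that isolates a single change. With the same atoms joined differently at this one place, compound 1 and compound 3 cannot be told apart on this read-out, something the earlier pair, which differs at more than one place, could not show. No measurement at hand offers an explanation for this result.

As far as these compounds go, the result covers only these two methylphenyl groups, so it remains open whether 2-methylphenyl, an amine or a carboxylic acid on this phenyl ring, or a longer chain in place of the methyl group, would stay within the same span of numbers. Among these compounds, how the gap between compound 1 and compound 2 divides among their several differences also remains unresolved, with no single-place step linking the two.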